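Working notes on compounds 1 to 3

This account rests on a few compounds, and the source may have more. Where it says the series, first, only, none or still open, it means among the compounds named here.

Measured so far:
compound 1 `CCn1cc(-c2nnc(COc3ccc4ccccc4c3)o2)c(=O)c2cc(F)c(N3CCNCC3)cc21` — in a functional assay on A549 cells (Homo sapiens) for cytotoxicity, read by MTT assay (a higher number here means a weaker inhibitor, a lower number a stronger inhibitor), compound 1 gives 80.2 ug/mL
compound 2 `CCn1cc(-c2nnc(-c3ccc(Nc4ccccc4)cc3)o2)c(=O)c2cc(F)c(N3CCNCC3)cc21` — in this assay compound 2 gives 88.6 ug/mL

Both measured compounds share the same core and differ only in the group carried on the five-membered ring; both sit at weak inhibition. Compound 2 holds the higher of the two numbers, but compound 1 is the nearest and the gap between them lies within the scatter, so no order between compound 1 and compound 2 can be read from these two values.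

Compound 3 `CCn1cc(-c2nnc(-c3ccc([N+](=O)[O-])cc3)o2)c(=O)c2cc(F)c(N3CCNCC3)cc21` is not yet measured. Among the measured compounds shown here, its single change from compound 2 is nitro in place of anilino on an aromatic carbon. For the measured compounds named here, no measured step covers a change of this kind, so the expectation rests on the two values given: compound 2 at 88.6 ug/mL and compound 1 at 80.2 ug/mL lie close together despite differing groups at the same place. For compound 3 a step of at most modest size is expected, in either direction, most likely none beyond the scatter.

Compound 3 is therefore estimated at 85 ug/mL in this assay, with a range from 40 ug/mL to 170 ug/mL. The expected step is a 1.0-fold lower number from compound 2 to compound 3 (0.02 log units; within the scatter).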

Compound 3, half-maximal inhibitory concentration: 74.3 ug/mL
Compound 3: middle estimate off by 1.1-fold (0.06 log units), on the high side; measured number inside the range.
By their numbers in this assay, from the lowest: compounds 3, 1 and 2 (each within the scatter of the next).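

In this assay, the exchange of anilino for nitro on an aromatic carbon, para to a large group, gives a 1.2-fold lower number from compound 2 to compound 3 (0.08 log units; within the scatter), so removing the anilino ring and its hydrogen-bond donor leaves no readable mark on the number at this position. The wider exchange of ((naphthalen-2-yl)oxy)methyl for 4-nitrophenyl gives a 1.1-fold lower number from compound 1 to compound 3 (0.03 log units; within the scatter), and the three compounds now show that quite different groups on the five-membered ring can all sit within the scatter of one another in this assay. No measured evidence bears on this flat result, and no explanation for it can be offered.

On these data alone, whether this flatness holds for other kinds of group remains open: an amine or a carboxylic acid in place of nitro, or a longer chain in place of ((naphthalen-2-yl)oxy)methyl, might or might not produce a step beyond the scatter. The shared core is the same in all three compounds, so these values say nothing about changes made elsewhere on it, or about what would move the number in either direction.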